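A few compounds are considered here, and "the series" means these few. Any claim that something is new, unique, unknown or untested is made for them only; others in the source may bear on it.

Measured in a functional assay on MDA-MB-231 cells (Homo sapiens) for cytotoxicity, read by sulforhodamine B assay, tested at 10 uM; on this read-out lower numbers stand for less inhibition and higher numbers for more inhibition at the one concentration tested (going by the name of the read-out):
compound 1, `CCCc1cc(-c2cn([C@H]3C[C@H](OC(C)=O)[C@@H](COC(C)=O)O3)c(=O)[nH]c2=O)on1` — 102%
compound 2, `CCCCCc1cc(-c2cn([C@H]3C[C@H](OC(C)=O)[C@@H](COC(C)=O)O3)c(=O)[nH]c2=O)on1` — 91.5%
compound 3, `CC(=O)OC[C@H]1O[C@@H](n2cc(-c3cn(Cc4ccc(C(C)C)cc4)nn3)c(=O)[nH]c2=O)C[C@@H]1OC(C)=O` — 98.1%

Compound 2 gives the lowest of the three numbers. Its nearest neighbour is compound 3, whose number lies within the scatter of that of compound 2, so no order between the two can be read. Compound 1 lies furthest away, and the step of a number 10.5 percentage points lower from compound 1 to compound 2 (beyond the scatter) goes beyond the scatter.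

The compound still to be measured is compound 4, `CC(=O)OC[C@H]1O[C@@H](n2cc(-c3cc(-c4ccc(C(C)(C)C)cc4)no3)c(=O)[nH]c2=O)C[C@@H]1OC(C)=O`. It differs from compound 2 in one place: 4-(tert-butyl)phenyl in place of pentyl on an aromatic carbon. Within the data shown here, the only measured step at this position is a number 10.5 percentage points lower from compound 1 to compound 2 (beyond the scatter), where ethyl in place of hydrogen on a saturated chain carbon went with a modestly lower number. That step does not cover an aromatic group in place of the chain. Compound 3, which also carries a phenyl, gives 98.1%, within the scatter of the number for compound 2, and no single-step comparison to it exists. Compound 4 is therefore expected to land near compound 2, with the step of a number 3.5 percentage points higher from compound 2 to compound 4 (within the scatter) expected to stay within the scatter. The estimate for compound 4 is 95%, with a range from 80% to 105%.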

Compound 4, a percentage reported as inhibition, at one concentration (the size of the read-out at that concentration, not a potency): 69.3%
Estimate against measurement, compound 4: 25.7 percentage points above; the measured number lies below the stated range.
By their numbers in this assay, from the lowest: compound 4; then compounds 2, 3 and 1 (each within the scatter of the next, the first and the last beyond it).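

In this assay, the change from a chain to an aromatic substituent on the carbon next to the ring nitrogen gives the first clear drop at this position: 4-(tert-butyl)phenyl in place of pentyl goes with a number 22.2 percentage points lower from compound 2 to compound 4 (beyond the scatter), and the same group in place of propyl goes with a number 32.7 percentage points lower from compound 1 to compound 4 (beyond the scatter). Among these compounds, the earlier compounds showed only a change of chain length at this carbon, a number 10.5 percentage points lower from compound 1 to compound 2 (beyond the scatter), so the position had been seen only with saturated chains, and the step from propyl to 4-(tert-butyl)phenyl now shows that the number here can move much further than that chain step did. Nothing available explains why this substituent goes with a lower number in the assay.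

The compounds shown cannot separate the contribution of the six-membered aromatic ring from that of its tert-butyl group, and a plain phenyl, a phenyl carrying a methoxy group or a carboxylic acid, or a longer chain such as heptyl at this carbon would bear on that question. With one tested concentration, they also leave open how the compounds would compare across a range of concentrations.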